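The source may report more compounds than this note shows. Statements on the series, on what has been measured and on what is new or still open speak of the compounds shown alone.

Measured so far in a functional assay on the whole organism (Tail, strain ICR) with Mus musculus as the target, in the tail flick test, with a stated time of 90 min, at a dose of 25 umol/kg by the oral route; a lower number here means a weaker effect, a higher number a stronger effect of the compound at the dose given:
compound 1 `NC(=O)CC[C@H](NC(=O)CN(c1ncnc2c1ncn2C1CCCCO1)C1CC1)C(=O)OCc1ccccc1` gives 37.8%;
compound 2 `NCCCC[C@H](NC(=O)CN(c1nc(Cl)nc2[nH]cnc12)C1CC1)C(=O)OCc1ccccc1` gives 35.3%;
compound 3 `CSCC[C@H](NC(=O)CN(c1nc(Cl)nc2[nH]cnc12)C1CC1)C(=O)O` gives 14%.

Compound 1 holds the highest of these three numbers, yet compound 2 sits within the usual scatter of it, so the two cannot be ranked; only compound 3 lies clearly beyond that scatter. Compound 4 `CSCC[C@H](NC(=O)CN(c1ncnc2c1ncn2C1CCCCO1)C1CC1)C(=O)OCc1ccccc1` has not yet been tested in this assay. It departs from compound 1 in one place: methylsulfanyl in place of carbamoyl on a saturated chain carbon, three bonds along the chain from an amide-type nitrogen and a carbonyl carbon. Going by the values given here, no measured pair shows this change on its own, so its size is unknown. The step is expected to be small, a modest drop that need not exceed the scatter, as a number 7.8 percentage points lower from compound 1 to compound 4 (within the scatter). Compound 4 is therefore estimated at 30%, within 15% to 45%.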

Compound 4, a percentage reported as activity, at one dose (the size of the read-out at that dose, not a potency): 42.7%
Compound 4: the middle estimate sits 12.7 percentage points below what was measured; low and high end bracket the measured number.
By their numbers in this assay, from the lowest: compound 3; then compounds 2, 1 and 4 (each within the scatter of the next).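

In this assay, going by these compounds alone, putting methylsulfanyl in place of carbamoyl on this saturated chain carbon gives a number 4.9 percentage points higher from compound 1 to compound 4 (within the scatter), the first direct reading of this change. At this position, then, the carbamoyl group with its hydrogen-bond donor can give way to a group with no donor, and the read-out stays within the scatter. This holds only for the core of compound 1 and for this single pair.

On these data alone, whether an amine, a carboxylic acid or a longer chain at this carbon would also stay within the scatter remains open. The data offer no independent measurement that would explain this result.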